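Notes on the aryl exchange on the aromatic nitrogen

The source may hold more compounds than are shown below. What is called first, only, known or untested is meant among the compounds shown, and "the series" means these compounds.

In a functional assay on PC-12 cells (Rattus norvegicus) for cytotoxicity, read by MTT assay, with stated times of 2 h and 24 h, tested at 10 uM (on this read-out higher numbers stand for a stronger effect at the one concentration tested and lower numbers for a weaker effect), compound 1 `Oc1cc(C(F)(F)F)ccc1-c1nc(-c2ccccc2O)n(-c2ccc(F)cc2)n1` gives 99.8%. Compound 2 `Oc1cc(C(F)(F)F)ccc1-c1nc(-c2ccccc2O)n(-c2ccccc2F)n1` gives 100% and compound 3 `Oc1cc(C(F)(F)F)ccc1-c1nc(-c2ccccc2O)n(-c2ccc(F)cc2F)n1` gives 97.9%. On these three numbers compound 1 stands second highest; the step of a number 0.2 percentage points higher from compound 1 to compound 2 (within the scatter) and the step of a number 1.9 percentage points lower from compound 1 to compound 3 (within the scatter) both lie within the scatter, as does a number 2.1 percentage points lower from compound 2 to compound 3 (within the scatter). All three numbers sit close to the top of the read-out.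

Compound 4 `Oc1cc(C(F)(F)F)ccc1-c1nc(-c2ccccc2O)n(-c2ccc(Cl)cc2Cl)n1` is unmeasured. Against compound 1 the change is 2,4-dichlorophenyl in place of 4-fluorophenyl on an aromatic nitrogen. The measured steps that bear on it are the exchange of the aryl group on the aromatic nitrogen, a number 0.2 percentage points higher from compound 1 to compound 2 (within the scatter), and the fluoro in place of hydrogen on an aromatic carbon, a number 1.9 percentage points lower from compound 1 to compound 3 (within the scatter) and a number 2.1 percentage points lower from compound 2 to compound 3 (within the scatter); none of them moved the number beyond the scatter. Halogen placement and halogen count on the aryl group at this position have so far left this assay unchanged, so no step beyond the scatter is expected for compound 4. Chlorine in place of fluorine has no measured precedent in the series, which widens the range rather than shifting the middle. Compound 4 is therefore expected to give 98%, within 85% to 100%, an expected step of a number 1.8 percentage points lower from compound 1 to compound 4 (within the scatter).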

Compound 4, a percentage reported as activity, at one concentration (the size of the read-out at that concentration, not a potency): 95.2%
Compound 4: the middle estimate sits 2.8 percentage points above what was measured; the range from low to high includes it.
By their numbers in this assay, from the lowest: compounds 4, 3, 1 and 2 (each within the scatter of the next).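

For the compounds shown here, the 2,4-dichlorophenyl group brings chlorine onto the aryl group on the aromatic nitrogen, a halogen the earlier compounds did not carry here, and in this assay the three new steps all stay within the scatter: a number 4.6 percentage points lower from compound 1 to compound 4 (within the scatter), a number 2.7 percentage points lower from compound 3 to compound 4 (within the scatter) and a number 4.8 percentage points lower from compound 2 to compound 4 (within the scatter). The closest comparison is the exchange of 2,4-difluorophenyl for 2,4-dichlorophenyl, so exchanging both fluorines for chlorines at this position does not move the number beyond the scatter, and none of the four compounds goes against this. No measurement in hand offers a reason for these numbers, or for their closeness.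

On these data alone, all four values lie near the top of a read-out taken at one concentration, so it remains open whether these aryl groups would separate at lower concentrations, where the read-out is not so close to its top. Also open, as far as these compounds go, is whether the position keeps this insensitivity with a group that carries no halogen, such as an unsubstituted phenyl, a 4-methoxyphenyl, or an aryl group bearing an amine or a carboxylic acid, or with a simple alkyl chain in place of the aryl ring.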